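Benzofuranyl Phenols with Aminomethyl Side Chains: Cytotoxicity Notes

The source may report more compounds than this note shows. Statements on the series, on what has been measured and on what is new or still open speak of the compounds shown alone.

Measured so far:
compound 1 `CCN(CC)Cc1c(O)ccc2oc(Cc3ccccc3)cc12`: 12000 nM
compound 2 `NC(=O)C1CCN(Cc2c(O)ccc3oc(Cc4ccccc4)cc23)CC1`: 85000 nM

In a functional assay on SQ20B cells (Homo sapiens) for cytotoxicity, read by MTT assay, with a stated time of 72 h (a lower number here means a stronger inhibitor, a higher number a weaker inhibitor), compound 2 gives 85000 nM, the highest number of the two measured compounds; its nearest neighbour is compound 1, and the step of a 7.1-fold higher number from compound 1 to compound 2 (0.85 log units; beyond the scatter) lies beyond the scatter.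

Compound 3 `Oc1ccc2oc(Cc3ccccc3)cc2c1CN1CCC(N2CCCCC2)CC1` is not yet measured. It differs from compound 2 by piperidin-1-yl in place of carbamoyl on a saturated ring carbon. Within the data shown here, the only step that bears on this change is a 7.1-fold higher number from compound 1 to compound 2 (0.85 log units; beyond the scatter), where the carbamoyl-bearing ring replaced diethylamino and the number rose. Among the measured compounds shown here, removing the carbamoyl in compound 3 undoes part of what that step introduced, so a modest fall in this assay is expected, pointing back toward the number of compound 1, though the piperidin-1-yl that enters has no measured precedent here.

For compound 3 the expected value in this assay is 20000 nM (range 6000 nM to 70000 nM), the expected step being a 4.3-fold lower number from compound 2 to compound 3 (0.63 log units; beyond the scatter).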

Compound 3, half-maximal inhibitory concentration: 3000 nM
Compound 3: the middle estimate sits 6.7-fold (0.82 log units) above what was measured; measured number below the stated range.
By their numbers in this assay, from the lowest: compound 3; then compound 1; then compound 2.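

In this assay, a 28-fold lower number from compound 2 to compound 3 (1.45 log units; beyond the scatter) shows that a change at this one saturated ring carbon, three ring bonds from the ring nitrogen, can move the number by a large step with the rest of the amine side chain held fixed; the earlier comparison replaced the whole amine. The change does more than reverse a 7.1-fold higher number from compound 1 to compound 2 (0.85 log units; beyond the scatter), since compound 1 gives 12000 nM and compound 3 gives 3000 nM. Nothing measured on these compounds accounts for the step.

Going by these compounds, it remains open whether the fall follows from the loss of carbamoyl or from the entry of piperidin-1-yl. A dimethylamino, morpholin-4-yl or carboxylic acid group on the same ring carbon would help to separate these readings.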